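Two Methyls on the Phenyl Ring: Compound 4 Estimated

The source may hold more compounds than are shown below. What is called first, only, known or untested is meant among the compounds shown, and "the series" means these compounds.

The compounds measured so far in a functional assay on HCT-116 cells (Homo sapiens) for inhibition, read by CCK-8 assay, with a stated time of 48 h; a lower number here means a stronger inhibitor, a higher number a weaker inhibitor:
Compound 1 `COc1cc(-c2ccnc3cc(-c4ccc(-c5cnn(C)c5)cc4)nn23)cc(OC)c1OC`: compound 1 gives 2110 nM.
Compound 2 `COc1cc(-c2ccnc3cc(-c4ccccc4)nn23)cc(OC)c1OC`: compound 2 gives 3880 nM.
Compound 3 `CCOC(=O)c1ccc(-c2cc3nccc(-c4cc(OC)c(OC)c(OC)c4)n3n2)cc1`: for compound 3 the assay reports only a limit, > 10000 nM.

Among the two numbers shown in this assay, compound 2 stands highest, with compound 1 nearest at a 1.8-fold higher number from compound 1 to compound 2 (0.26 log units; within the scatter), a gap within the scatter; the third value is a limit (the limit of > 10000 nM in this assay, at which 1 of the 3 values shown sits).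

Compound 4 `COc1cc(-c2ccnc3cc(-c4ccc(C)c(C)c4)nn23)cc(OC)c1OC` differs from compound 2 in one place: 3,4-dimethylphenyl in place of phenyl on an aromatic carbon. The measured steps that bear on this change both alter the same aromatic carbon of the phenyl ring. The step of a 1.8-fold higher number from compound 1 to compound 2 (0.26 log units; within the scatter) lies within the scatter, whereas an at least 2.5-fold higher number from compound 2 to compound 3 (0.41 log units; beyond the scatter) runs beyond it toward weaker inhibition. Going by the values given here, a substituent on that ring has therefore either left the number where it was or raised it; no measured step shows it lowered. For compound 4, with two methyl groups entering, the expectation in this assay is a step of roughly a 1.1-fold lower number from compound 2 to compound 4 (0.04 log units; within the scatter), that is, no change beyond the scatter. Compound 4 is accordingly estimated at 3500 nM, with a likely range from 1200 nM to 10000 nM.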

Compound 4, half-maximal inhibitory concentration: 261 nM
Compound 4: the middle estimate sits 13-fold (1.13 log units) above what was measured, outside the stated range (below it).
By their numbers in this assay, from the lowest: compound 4; then compounds 1 and 2 (each within the scatter of the next). At a limit, above all of these: compound 3.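

In this assay the change from phenyl to 3,4-dimethylphenyl gives a 15-fold lower number from compound 2 to compound 4 (1.17 log units; beyond the scatter), and this is the first step among the compounds shown in which a substituted ring on this carbon, next to the ring nitrogen, lowers the number beyond the scatter. The earlier steps shown here on the same ring gave no such sign, since a 1.8-fold higher number from compound 1 to compound 2 (0.26 log units; within the scatter) stayed within the scatter and an at least 2.5-fold higher number from compound 2 to compound 3 (0.41 log units; beyond the scatter) ran toward weaker inhibition, so the position is now seen to respond in both directions, with the outcome depending on which group enters and compound 3 standing against any rule that substitution here helps. Nothing given here accounts for the size of the step to compound 4.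

The compounds shown leave open whether a single methyl group would carry this step or whether both methyl groups of compound 4 are needed. They also leave open whether a longer chain such as ethyl, a methoxy group, a chlorine atom or an amine on this phenyl ring would keep the number as low as in compound 4.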